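The compounds below may be only part of what the source reports. "The series", "measured", "known", "first", "only" and "open" are said of these compounds alone.

Measured compounds:
compound 1, `COc1cccc(Sc2c(NS(=O)(=O)c3ccc(C(C)(C)C)cc3)noc2CCCC#N)c1`, an assay on COS-7 cells for displacement of a labelled ligand from Endothelin receptor type B (Sus scrofa); a higher number here means a weaker inhibitor, a lower number a stronger inhibitor: 520 nM
compound 2, `COC(=O)CCCc1onc(NS(=O)(=O)c2ccc(C(C)(C)C)cc2)c1Sc1cccc(OC)c1`, this assay: 310 nM
compound 3, `COc1cccc(Sc2c(NS(=O)(=O)c3ccc(C(C)(C)C)cc3)noc2CCCC(=O)O)c1`, this assay: 500 nM

Compound 3 stands second highest of these three numbers, but a 1.0-fold lower number from compound 1 to compound 3 (0.02 log units; within the scatter) and a 1.6-fold higher number from compound 2 to compound 3 (0.21 log units; within the scatter) both remain within the scatter, so the three compounds sit together rather than in any order.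

Compound 4, `COc1cccc(Sc2c(NS(=O)(=O)c3ccc(C(C)(C)C)cc3)noc2CCCC(C)=O)c1`, differs from compound 3 in one place: methyl in place of hydroxy on a carbonyl carbon. Cut one bond further out, this reads carboxy to acetyl. Within the data shown here, no measured step makes this same change; the closest are a 1.6-fold higher number from compound 2 to compound 3 (0.21 log units; within the scatter), which alters the same carbonyl group, and a 1.7-fold lower number from compound 1 to compound 2 (0.22 log units; within the scatter), and both lie within the scatter. Three different chain ends have given numbers within the scatter of one another, so this further change of chain end is expected to give no step beyond the scatter: a 1.2-fold lower number from compound 3 to compound 4 (0.08 log units; within the scatter). Compound 4 is therefore estimated at 420 nM, with a range from 160 nM to 1100 nM.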

Compound 4, half-maximal inhibitory concentration: 400 nM
Beside the measured number, compound 4's estimate is 1.1-fold (0.02 log units) above it; the range from low to high includes it.
By their numbers in this assay, from the lowest: compounds 2, 4, 3 and 1 (each within the scatter of the next).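

Swapping the hydroxy of the carboxy group for methyl removes the chain end's hydrogen-bond donor, yet this assay shows a 1.3-fold lower number from compound 3 to compound 4 (0.10 log units; within the scatter). The acetyl end also stays level with the other two chain ends, with a 1.3-fold higher number from compound 2 to compound 4 (0.11 log units; within the scatter) and a 1.3-fold lower number from compound 1 to compound 4 (0.11 log units; within the scatter), so among these four compounds the number does not follow whether that donor is present. Nothing available explains why these chain ends give such similar numbers. As far as these compounds go, it remains open whether an amine at the chain end, or a shorter or longer chain, would give a step beyond the scatter.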